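This account rests on a few compounds, and the source may have more. Where it says the series, first, only, none or still open, it means among the compounds named here.

Compound 1 `COc1ccc(OC)c(Nc2cc(Nc3ccc(F)cc3)ncn2)c1` gives 230 nM in an assay for inhibition of Receptor tyrosine-protein kinase erbB-3 variant L858R (Homo sapiens), read by mobility shift assay, with a stated time of 10 min; on this read-out lower numbers stand for stronger inhibition and higher numbers for weaker inhibition. Compound 3 `Clc1ccc(Nc2cc(Nc3cccc(Cl)n3)ncn2)cc1` gives 236 nM, a number within the scatter of compound 1, while compound 2 `O=C(O)CCC(=O)Nc1cc(Nc2ccc(Cl)cc2)ncn1` gives 825 nM, the highest of the three numbers. Within the data shown here, the one step among the measured compounds, a 3.5-fold lower number from compound 2 to compound 3 (0.54 log units; beyond the scatter), concerns a change on a ring nitrogen substituent and not the aromatic carbon altered here. Compound 4 `COc1ccc(OC)c(Nc2cc(Nc3ccc(S(N)(=O)=O)cc3)ncn2)c1` differs from compound 1 by sulfamoyl in place of fluoro on an aromatic carbon. Among the measured compounds shown here, no measured step bears on this change, so the expectation rests on compound 1 alone and is estimated as a step of a 1.3-fold higher number from compound 1 to compound 4 (0.12 log units; within the scatter), with no direction established beyond the scatter. Compound 4 is therefore expected to give about 300 nM, within a range of 90 nM to 1000 nM.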

Compound 4, half-maximal inhibitory concentration: 619 nM
The estimate for compound 4 lay 2.1-fold (0.31 log units) below the measured number; low and high end bracket the measured number.
By their numbers in this assay, from the lowest: compounds 1 and 3 (each within the scatter of the next); then compounds 4 and 2 (each within the scatter of the next).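

At this aromatic carbon, para to a large group, sulfamoyl in place of fluoro gives a 2.7-fold higher number from compound 1 to compound 4 (0.43 log units; beyond the scatter) in this assay, which shows that the number responds to this substitution by more than the scatter, and in the direction of weaker inhibition. The step is modest, so inhibition is reduced and not lost with sulfamoyl here. Nothing measured here accounts for this step. On these data alone, whether an amine or a carboxylic acid on this carbon would keep the number near that of compound 1 stays open, as does whether a smaller sulfonyl-free group would do so.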